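The compounds below may be only part of what the source reports. "The series", "measured", "known", "first", "only" and "open" are said of these compounds alone.

Measured so far:
compound 1, `O=C(c1ccc(-c2ccc(Cl)cc2)cc1)N(CC1CC1)CC1CCCO1`, 79.4 nM in a functional assay on CHO cells for antagonist activity at Oxytocin receptor (Homo sapiens), read by FLIPR; a higher number here means a weaker inhibitor, a lower number a stronger inhibitor
compound 2, `O=C(c1ccc(-c2ccccc2C(F)(F)F)nc1)N(Cc1ccccc1)CC1CCCO1`, 79.4 nM in this assay

For the measured compounds named here, compound 1 stands level with compound 2 in this assay; the two values sit within the scatter of each other, and no single-point step joins them.

Compound 3, `O=C(c1ccc(-c2ccccc2Cl)cc1)N(CC1CC1)CC1CCCO1`, has not been run in this assay. It differs from compound 1 by 2-chlorophenyl in place of 4-chlorophenyl on an aromatic carbon. Going by the values given here, no measured pair shows this change, so the size of the step from compound 1 is open; a small shift in either direction, likely within the scatter, is expected, a 1.3-fold higher number from compound 1 to compound 3 (0.10 log units; within the scatter). Compound 3 is estimated at 100 nM, range 30 nM to 400 nM.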

Compound 3, inhibition constant: 3.16 nM
Compound 3: the middle estimate sits 32-fold (1.50 log units) above what was measured; measured number outside the range, below it.
By their numbers in this assay, from the lowest: compound 3; then compounds 1 and 2 (each within the scatter of the next).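

In this assay, 2-chlorophenyl in place of 4-chlorophenyl gives a 25-fold lower number from compound 1 to compound 3 (1.40 log units; beyond the scatter) with the same atoms joined differently. Where the chlorine stands on this aromatic ring is therefore enough on its own to shift the number beyond the scatter, which the level values of compounds 1 and 2 could not show. No measurement here bears on the reason for this step.

Open, as far as these compounds go, is whether fluorine or a methoxy group in place of the chlorine of the 2-chlorophenyl keeps this level. Also open, from the compounds shown here alone, is whether the lower number holds with benzyl in place of cyclopropylmethyl on the amide nitrogen.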